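A few compounds are considered here, and "the series" means these few. Any claim that something is new, unique, unknown or untested is made for them only; others in the source may bear on it.

The measured compounds and their values in an ADME assay on BJ cells (Homo sapiens) for antiproliferative activity, with a stated time of 72 h (a higher number here means that more compound is needed for the effect, a lower number that less compound is needed), are these. Compound 1 `COc1ccc(-c2cc(=O)c3c(OC)cc(OC)cc3n2S(=O)(=O)c2ccc(C=O)cc2)cc1` is reported only as a limit, > 34400 nM. Compound 2 `COc1ccc(-c2cc(=O)c3c(OC)cc(OC)cc3n2S(=O)(=O)c2ccc(C#N)cc2)cc1` is likewise reported only as a limit, > 17200 nM. Compound 3 `COc1ccc(-c2cc(=O)c3c(OC)cc(OC)cc3n2S(=O)(=O)c2cc(Cl)cc(Cl)c2O)cc1` is also reported only as a limit, > 37900 nM.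

Compound 3 therefore does not stand at a number in this assay at all: all three values shown are limits, and none of the three steps among them can be read. The step from compound 1 to compound 2 is a step that the two limits leave unreadable from compound 1 to compound 2, the step from compound 1 to compound 3 is a step that the two limits leave unreadable from compound 1 to compound 3, and the step from compound 2 to compound 3 is a step that the two limits leave unreadable from compound 2 to compound 3.

Compound 4 `COc1ccc(-c2cc(=O)c3c(OC)cc(OC)cc3n2S(=O)(=O)Cc2ccccc2)cc1` differs from compound 3 by benzyl in place of 3,5-dichloro-2-hydroxyphenyl on a sulfonyl sulfur. Within the data shown here, the two measured steps that touch the group on the sulfonyl sulfur, from compound 1 to compound 3 and from compound 2 to compound 3, both remain unreadable, so no measured step tells how large a change on this sulfur produces in this assay. What the three limits do show is that every variation of the group on the sulfonyl sulfur tried so far has left the compound without a readable effect.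

The expectation for compound 4 is therefore another limit rather than a number: compound 4 is estimated at 40000 nM, within 15000 nM to 150000 nM. The step from compound 3 to compound 4 that this estimate implies is expected to be a step that the limit leaves unreadable from compound 3 to compound 4.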

Compound 4, half-maximal effective concentration: > 34400 nM
Compound 4: only a limit was reported; the forecaster's own chance of this, stated with the estimate: 85%; the middle value does not contradict the limit.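

In this assay compound 4 is again reported only as a limit, > 34400 nM, so its steps from compound 1, compound 2 and compound 3 cannot be read. From the compounds shown here alone, with all four compounds given only as limits, what stays open is how much any change of the group on the sulfonyl sulfur alters the half-maximal effective concentration.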